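A few compounds are considered here, and "the series" means these few. Any claim that something is new, unique, unknown or untested is made for them only; others in the source may bear on it.

Measured compounds in an ADME assay on Caco-2 cells (Homo sapiens) for permeability, in the apical to basolateral direction; a lower number here means that the compound crosses the layer more slowly, a higher number that the compound crosses the layer faster:

Compound 1 `CNC(=O)c1cc(Oc2ccc3oc(Nc4ccc(OC(F)(F)F)cc4)nc3c2)ccn1` gives 10 10^-6 cm/s.
Compound 2 `CNC(=O)c1cc(Oc2ccc3sc(Nc4ccc(Cl)cc4)nc3c2)ccn1` gives 10 10^-6 cm/s.
Compound 3 `CNC(=O)c1cc(Oc2ccc3sc(Nc4ccc(C)cc4)nc3c2)ccn1` gives 10 10^-6 cm/s.

Compound 3 stands level with compound 1 and compound 2 at the digits shown; none of the three values can be told apart within the scatter. Within the data shown here, compound 1 and compound 2 differ in more than one place, so no single step is drawn between them; their two values simply coincide.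

The next compound is compound 4 `CNC(=O)c1cc(Oc2ccc3sc(Nc4ccc(C(C)C)cc4)nc3c2)ccn1`, which differs from compound 3 as follows: isopropyl in place of methyl on an aromatic carbon. Among the measured compounds shown here, one measured step bears on this: no change at the digits printed from compound 2 to compound 3 (within the scatter), a swap at the same aromatic carbon of the same ring, which left this assay unchanged. The change from compound 3 to compound 4 keeps the substituent at that carbon neutral and without donors or acceptors, adding only two further carbons; nothing in the series shows a step of this kind moving the permeability.

The expected outcome is therefore no step beyond the scatter, no change at the digits printed from compound 3 to compound 4 (within the scatter), in either direction. Compound 4 is estimated at 10 10^-6 cm/s in this assay, with a range from 5 10^-6 cm/s to 20 10^-6 cm/s.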

Compound 4, apparent permeability: 10 10^-6 cm/s
Estimate against measurement, compound 4: no gap at the digits printed, and the stated range covers the measured number.
By their numbers in this assay, from the lowest: compounds 1, 2, 3 and 4 (each within the scatter of the next).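

In this assay, going from 4-methylphenyl to 4-isopropylphenyl, with three heavy atoms at this carbon in place of one, gives no change at the digits printed from compound 3 to compound 4 (within the scatter) and so extends the earlier chloro-to-methyl comparison to a branched alkyl group. Taken directly against the chloro analogue, the isopropyl swap gives no change at the digits printed from compound 2 to compound 4 (within the scatter), so chloro, methyl and isopropyl, all without hydrogen-bond donors or acceptors and without net charge, cannot be told apart at this aromatic carbon para to a large group in this assay. No measured evidence accompanies these steps to account for the flat read-out.

Still open, on these data alone, is whether this level holds for groups of a different kind at the same carbon, such as a carboxylic acid, a primary amine or a longer chain ending in a hydroxyl group, since every group compared here is a halogen or a small alkyl group. Compound 1 differs from the others in more than one place, so the contribution of its trifluoromethoxy group cannot be read on its own.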